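Hydrazone replacement at the imine nitrogen of compound 2

This account rests on a few compounds, and the source may have more. Where it says the series, first, only, none or still open, it means among the compounds named here.

Of the compounds shown here, three have numbers so far. Compound 1 `O=c1cc(/C=N\c2ccccc2O)c2c(OCc3ccccc3)cc(OCc3ccccc3)cc2o1` gives 7760 nM in a functional assay, read by spectrophotometry, with a stated time of 3 min; a lower number here means a stronger inhibitor, a higher number a weaker inhibitor. Among the compounds with values here, compound 3 `O=c1cc(/C=N\O)c2c(OCc3ccccc3)cc(OCc3ccccc3)cc2o1` differs from it only at the double-bonded nitrogen and gives 38700 nM; the step of a 5.0-fold higher number from compound 1 to compound 3 (0.70 log units; beyond the scatter) is the one measured change at that nitrogen. Compound 2 `O=c1cc(/C=N\c2ccc(O)cc2)c2ccc(OCc3ccccc3)cc2o1` carries a single benzyloxy group on the shared core and stands highest of the three with 64500 nM, its gap to compound 3 within the scatter and its gap to compound 1 beyond it.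

Compound 4 `O=c1cc(/C=N\Nc2ccc([N+](=O)[O-])cc2)c2ccc(OCc3ccccc3)cc2o1` is not yet measured. It differs from compound 2 by (4-nitrophenyl)amino in place of 4-hydroxyphenyl on a double-bonded nitrogen. Within the data shown here, no measured pair swaps an aryl for an arylamino at this nitrogen, so the only step that bears on it is the change at the same nitrogen from compound 1 to compound 3, which was modest. The number in this assay is therefore expected to move by no more than a modest amount, with a slight lean toward a lower number; the expected step is a 2.2-fold lower number from compound 2 to compound 4 (0.33 log units; beyond the scatter). For compound 4 the estimate is 30000 nM, within 8000 nM to 120000 nM.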

Compound 4, half-maximal inhibitory concentration: 9510 nM
For compound 4 the middle estimate is 3.2-fold (0.50 log units) above the measured one; the range from low to high includes it.
By their numbers in this assay, from the lowest: compounds 1 and 4 (each within the scatter of the next); then compounds 3 and 2 (each within the scatter of the next).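

On the core with a single benzyloxy group, the double-bonded nitrogen proves sensitive to substitution: in this assay, (4-nitrophenyl)amino in place of 4-hydroxyphenyl gives a 6.8-fold lower number from compound 2 to compound 4 (0.83 log units; beyond the scatter). Within the data shown here, the only earlier change at this nitrogen, a 5.0-fold higher number from compound 1 to compound 3 (0.70 log units; beyond the scatter), ran toward a higher number on a different core, so this position can move the number in either direction, depending on the group and core involved. No supporting data bear on why the number moves here.

The change combines an added amino link with a nitro group in place of the hydroxy group, and the compounds shown do not separate the two. On these data alone, it remains open whether a plain phenylamino group, or a 4-nitrophenyl group placed directly on this nitrogen, would give a comparable step.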